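A few compounds are considered here, and "the series" means these few. Any claim that something is new, unique, unknown or untested is made for them only; others in the source may bear on it.

Compound 1 `CN(CCNCc1cn(-c2ccccc2)nn1)CCNc1ccnc2cc(Cl)ccc12`: 25000 nM
Compound 2 `CN(CCNCc1cn(-c2cccc(Cl)c2)nn1)CCNc1ccnc2cc(Cl)ccc12`: 17000 nM
Compound 3 `CN(CCNCc1cn(Cc2ccc(Br)cc2)nn1)CCNc1ccnc2cc(Cl)ccc12`: 12000 nM

In a functional assay on NCI-H460 cells (Homo sapiens) for antiproliferative activity, read by sulforhodamine B assay, with a stated time of 72 h (a lower number here means a stronger inhibitor, a higher number a weaker inhibitor), compound 1 gives 25000 nM, the highest of the three numbers; compound 2 sits nearest, with a 1.5-fold lower number from compound 1 to compound 2 (0.17 log units; within the scatter), and compound 3 furthest, with a 2.1-fold lower number from compound 1 to compound 3 (0.32 log units; beyond the scatter). Compound 4 `CN(CCNCc1cn(-c2ccnc3cc(Cl)ccc23)nn1)CCNc1ccnc2cc(Cl)ccc12` has not been measured; it differs from compound 1 in one place: 7-chloroquinolin-4-yl in place of phenyl on an aromatic nitrogen. Within the data shown here, two measured steps bear on this: the earlier change at the same ring nitrogen, a 2.1-fold lower number from compound 1 to compound 3 (0.32 log units; beyond the scatter), a modest lowering, and the added chloro on an aromatic carbon, a 1.5-fold lower number from compound 1 to compound 2 (0.17 log units; within the scatter), which stayed within the scatter. A downward step of similar modest size is therefore expected, a 2.1-fold lower number from compound 1 to compound 4 (0.32 log units; beyond the scatter). Compound 4 is estimated at 12000 nM, within 5000 nM to 30000 nM.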

Compound 4, half-maximal inhibitory concentration: 16000 nM
For compound 4 the middle estimate is 1.3-fold (0.12 log units) below the measured one; the range from low to high includes it.
By their numbers in this assay, from the lowest: compounds 3, 4, 2 and 1 (each within the scatter of the next, the first and the last beyond it).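

At this ring nitrogen in this assay, putting 7-chloroquinolin-4-yl in place of phenyl stays within the scatter (a 1.6-fold lower number from compound 1 to compound 4 (0.19 log units; within the scatter)), so this larger group, which adds a hydrogen-bond acceptor, brings no clear change. It also cannot be told apart from 4-bromobenzyl (a 1.3-fold higher number from compound 3 to compound 4 (0.12 log units; within the scatter)) or 3-chlorophenyl (a 1.1-fold lower number from compound 2 to compound 4 (0.03 log units; within the scatter)). No measured evidence is available to explain this flat result.

On these data alone, whether a different kind of group at this nitrogen, such as an amine or a carboxylic acid on the benzyl ring, would shift the number more remains open.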